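The source may hold more compounds than are shown below. What is called first, only, known or untested is meant among the compounds shown, and "the series" means these compounds.

Three compounds have so far been measured in an assay on isolated protein for inhibition of NEDD8-activating enzyme E1 regulatory subunit (Homo sapiens), read by Western blot, with stated times of 10 min and 30 min, tested at 25 uM; a lower number here means less inhibition, a higher number more inhibition at the concentration tested (going by the name of the read-out):

compound 1 `CCOc1nc2cccc(C(=O)NCCCOC)c2n1Cc1ccc(-c2ccccc2-c2nnn[nH]2)cc1` gives 27.9%
compound 2 `CCOc1nc2cccc(C(=O)N[C@H]3CC[C@H](C(=O)OC)CC3)c2n1Cc1ccc(-c2ccccc2-c2nnn[nH]2)cc1` gives 28.6%
compound 3 `CCOc1nc2cccc(C(=O)Nc3ccccc3)c2n1Cc1ccc(-c2ccccc2-c2nnn[nH]2)cc1` gives 34.6%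

Compound 1 stands lowest of the three numbers, but the step of a number 0.7 percentage points higher from compound 1 to compound 2 (within the scatter) and the step of a number 6.7 percentage points higher from compound 1 to compound 3 (within the scatter) both stay within the scatter, so no order among the three compounds can be claimed from these numbers; the step of a number 6 percentage points higher from compound 2 to compound 3 (within the scatter) is likewise within the scatter.

Compound 4 `CCOc1nc2cccc(C(=O)Nc3ccc(F)cc3)c2n1Cc1ccc(-c2ccccc2-c2nnn[nH]2)cc1` has not yet been measured. It differs from compound 1 in one place: 4-fluorophenyl in place of 3-methoxypropyl on an amide-type nitrogen. The measured step that bears most directly on this change is a number 6.7 percentage points higher from compound 1 to compound 3 (within the scatter), in which a phenyl also took the place of the 3-methoxypropyl on the amide-type nitrogen. That step, and the related step of a number 6 percentage points higher from compound 2 to compound 3 (within the scatter), stayed within the scatter. On this basis compound 4 is expected to land close to compound 3 in this assay, with any shift from compound 1 not rising beyond the scatter. The expected step is a number 5.1 percentage points higher from compound 1 to compound 4 (within the scatter). For compound 4 the estimated value in this assay is 33%, within a range from 22% to 45%.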

Compound 4, a percentage reported as inhibition, at one concentration (the size of the read-out at that concentration, not a potency): 45.3%
Compound 4: the middle estimate sits 12.3 percentage points below what was measured, outside the stated range (above it).
By their numbers in this assay, from the lowest: compounds 1, 2 and 3 (each within the scatter of the next); then compound 4.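

In this assay, among the compounds shown here, fluoro in place of hydrogen on an aromatic carbon is the first change on this amide-type nitrogen to carry a step beyond the scatter, with a number 10.7 percentage points higher from compound 3 to compound 4 (beyond the scatter), modest in size but enough to set the 4-fluorophenyl amide apart from the unsubstituted phenyl amide. The 4-fluorophenyl group also clears the scatter against both non-aromatic groups, with a number 17.4 percentage points higher from compound 1 to compound 4 (beyond the scatter) in place of 3-methoxypropyl and a number 16.7 percentage points higher from compound 2 to compound 4 (beyond the scatter) in place of 4-(methoxycarbonyl)cyclohexyl, whereas the phenyl group had stayed within the scatter of each, so at this position a ring alone did not separate from the other groups but the fluorinated ring did. Nothing available explains this rise.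

The compounds shown leave open whether chloro, methyl or a nitrile in the same place on the phenyl ring would give a number like that of compound 4, or whether the rise belongs to fluoro alone. They also leave open how these compounds would order by potency, since each number is the size of the read-out at a single concentration.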